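Three Inactive Analogues and a Chlorophenylamino Newcomer

The source may report more compounds than this note shows. Statements on the series, on what has been measured and on what is new or still open speak of the compounds shown alone.

Compound 1 `C=C[C@@](C)(/C=C/c1ccc(OCc2ccccc2)cc1)CCC=C(C)C` gives > 52000 nM in a functional assay on HepG2 cells (Homo sapiens) for cytotoxicity, with a stated time of 72 h; on this read-out higher numbers stand for an effect only at larger amounts of compound and lower numbers for an effect already at smaller amounts; this is a limit of the assay.
Compound 2 `C=C[C@@](C)(/C=C/c1ccc(O)c(/C=C/c2ccc(Cl)c(Cl)c2)c1)CCC=C(C)C` gives > 52000 nM in this assay; this too is a limit.
Compound 3 `COc1ccc(/C=C/[C@@](C)(/C=C/c2ccc(O)c(/C=C/C(=O)OC(C)(C)C)c2)CCC=C(C)C)cc1` gives > 52000 nM in this assay; again only a limit.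

None of the three measured compounds yields a number in this assay. Within the data shown here, compound 1 stands at the same place as the other two: all three sit at the limit of the assay, as the single piece of evidence states (the limit of > 52000 nM in this assay, at which 3 of the 3 values shown sit). Among the measured compounds shown here, no step between measured compounds can therefore be read, and nothing in the data separates compound 1 from compound 2 or compound 3.

Compound 4 `C=C[C@@](C)(/C=C/c1ccc(Nc2ccc(Cl)cc2)cc1)CCC=C(C)C` has not yet been measured. It differs from compound 1 at one position: (4-chlorophenyl)amino in place of benzyloxy on an aromatic carbon. Since the data show no change that moved any value away from the limit, the step expected from compound 1 to compound 4 is none beyond the scatter, and compound 4 is most likely to come back as a limit as well. The expected step is a step that the limit leaves unreadable from compound 1 to compound 4. The estimate for compound 4 is 60000 nM, expected to lie between 20000 nM and 200000 nM.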

Compound 4, half-maximal effective concentration: > 52000 nM
Compound 4 was reported as a limit; the forecaster's own chance of this, stated with the estimate: 75%; the middle value is on the limit's open side.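

Like compound 1, compound 4 gives only a limit in this assay, so no step can be read between the two compounds: the limit of > 52000 nM in this assay, at which 4 of the 4 values shown sit. The compounds shown leave open whether any change to the shared core would bring a value within the measurable range of this assay, and how these compounds would then rank.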